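The source may hold more compounds than are shown below. What is called first, only, known or untested is meant among the compounds shown, and "the series" means these compounds.

Series notes. Compound 1 `CC1=C(C(=O)OC(C(F)(F)F)C(F)(F)F)C(c2ccsc2)NC(=O)N1`, compound 2 `CC1=C(C(=O)OCC(F)(F)F)C(c2ccsc2)NC(=O)N1` and compound 3 `CC1=C(C(=O)OC(C)C(F)(F)F)C(c2ccsc2)NC(=O)N1` share one core and differ only in the ester side chain. In an assay on cells for displacement of a labelled ligand from adenosine receptor A1 (Homo sapiens), read by radioligand binding, with a stated time of 60 min, tested at 1 uM (on this read-out lower numbers stand for less inhibition and higher numbers for more inhibition at the one concentration tested (going by the name of the read-out)), compound 1 gives 17%, compound 2 gives 2% and compound 3 gives 3%; 3% (2 entries). Among the measured compounds shown here, the only one-place step measured so far is a number 15 percentage points lower from compound 1 to compound 2 (beyond the scatter). Among the single numbers compound 2 stands lowest, with compound 1 the nearest entry above it; the values of compound 2 and compound 3 lie within the scatter of each other, so nothing separates them.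

Compound 4 `CC1=C(C(=O)OCC(F)(F)F)C(c2cccs2)NC(=O)N1` has not yet been measured. It keeps the ester of compound 2 and differs from it only in the ring attached to the saturated ring carbon: thiophen-2-yl in place of thiophen-3-yl on a saturated ring carbon. For the measured compounds named here, no measured step involves this change; the single step known, from compound 1 to compound 2, alters the ester chain while both compounds carry thiophen-3-yl, so it carries no information on thiophen-2-yl. Going by the values given here, with no bearing step, no shift beyond the scatter is expected in this assay, and compound 2 already sits near the bottom of the scale. The step expected from compound 2 to compound 4 is a number 3 percentage points higher from compound 2 to compound 4 (within the scatter). Compound 4 is estimated at 5%, with a range from -5% to 20%.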

Compound 4, a percentage reported as inhibition, at one concentration (the size of the read-out at that concentration, not a potency): 3%
The estimate for compound 4 lay 2 percentage points above the measured number; low and high end bracket the measured number.
By their numbers in this assay, from the lowest: compounds 2 and 4 (each within the scatter of the next); then compound 1.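

In this assay, among the compounds shown here, thiophen-2-yl in place of thiophen-3-yl on a saturated ring carbon gives a number 1 percentage points higher from compound 2 to compound 4 (within the scatter), the first measured change at this position of the shared core. With the ester of compound 2, the two thiophene attachments are therefore not told apart, and both compounds stay at the low end of the read-out, where a further fall would be hard to see at the one concentration tested. No supporting data bear on why the change leaves the number within the scatter.

For the compounds shown here, it remains open whether the same swap would also leave the number unchanged with the ester of compound 1, which at 17% is the only compound here clear of the low end and so has room to show a fall as well as a rise. From the compounds shown here alone, it is also open how a different group on this saturated ring carbon, such as phenyl, a pyridine ring or a chain bearing an amine, would read in this assay, since both groups compared here are thiophenes.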